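Swapping the Urea Arm for an Amide Arm

A few compounds are considered here, and "the series" means these few. Any claim that something is new, unique, unknown or untested is made for them only; others in the source may bear on it.

Measured so far:
compound 1 `COc1cc(-c2nn(-c3cccc(NC(=O)Nc4ccc(Cl)c(Cl)c4)c3)cc2-c2ccncc2)ccc1Cl` gives 2830 nM
compound 2 `O=C(Nc1cccc(-n2cc(-c3ccncc3)c(-c3ccc(Cl)c(O)c3)n2)c1)Nc1ccc(Cl)c(Cl)c1` gives only a limit, > 32500 nM

In a functional assay on PC-3 cells (Homo sapiens) for inhibition, read by sulforhodamine B assay, with a stated time of 48 h (a higher number here means a weaker inhibitor of growth, a lower number a stronger inhibitor of growth), compound 1 stands as the only real number shown, 2830 nM. Compound 2 reaches no number in this assay, only the limit > 32500 nM. Within the data shown here, the single measured step, an at least 11-fold higher number from compound 1 to compound 2 (1.06 log units; beyond the scatter), runs into the limit of > 32500 nM in this assay, at which 1 of the 2 values shown sits, and concerns a change at a different place. Compound 3 `COc1cc(-c2nn(-c3cccc(NC(=O)c4ccc(Cl)c(C(F)(F)F)c4)c3)cc2-c2ccncc2)ccc1Cl` differs from compound 1 by 4-chloro-3-(trifluoromethyl)phenyl in place of (3,4-dichlorophenyl)amino on a carbonyl carbon. Among the measured compounds shown here, no measured step covers this change, so the expectation rests on compound 1 alone: compound 3 is estimated at 3000 nM, within 800 nM to 12000 nM. The expected step, a 1.1-fold higher number from compound 1 to compound 3 (0.03 log units; within the scatter), is therefore no larger than the usual scatter.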

Compound 3, concentration for total growth inhibition: > 32500 nM
Compound 3: only a limit was reported (the forecaster's own chance of this, stated with the estimate: 10%); at least 10-fold (1.03 log units) between middle value and limit.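

In this assay the group on the carbonyl carbon proves not to be freely exchangeable: the step is an at least 11-fold higher number from compound 1 to compound 3 (1.06 log units; beyond the scatter) on placing 4-chloro-3-(trifluoromethyl)phenyl where (3,4-dichlorophenyl)amino stood. Compound 3 gives > 32500 nM as a limit of the assay, not a number. This second place is therefore also sensitive to change, and the full size of the loss cannot be read: the limit of > 32500 nM in this assay, at which 2 of the 3 values shown sit.

The compounds shown leave open whether the loss follows from losing the amino nitrogen or from the new ring substituents. A 4-chloro-3-(trifluoromethyl)phenylamino group on the same carbonyl carbon would separate the two.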